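The compounds below may be only part of what the source reports. "The series", "measured", "known", "first", "only" and "open" are said of these compounds alone.

Of the compounds shown here, two that share one core have been measured in a functional assay on KM12 cells (Homo sapiens) for inhibition, read by sulforhodamine B assay, with a stated time of 48 h, tested at 10 uM; on this read-out lower numbers stand for a stronger effect and higher numbers for a weaker effect at the one concentration tested. Compound 1 `COc1cc(Cl)cc(-c2nn(-c3cccc(NC(=O)c4cccc(C(F)(F)F)c4)c3)cc2-c2ccncc2)c1` carries a methoxy group and a single trifluoromethyl group; in this assay compound 1 gives 43.7%. Compound 2 `O=C(Nc1cccc(-n2cc(-c3ccncc3)c(-c3cc(O)cc(Cl)c3)n2)c1)c1cc(C(F)(F)F)cc(C(F)(F)F)c1` carries a hydroxy group in place of the methoxy and two trifluoromethyl groups; in this assay compound 2 gives 21.2%, the lower of the two numbers, and the gap to compound 1 lies beyond the usual scatter. Because these two compounds differ in more than one place, the numbers alone do not show which change carries the gap.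

Compound 3 `COc1cc(Cl)cc(-c2nn(-c3cccc(NC(=O)c4cc(C(F)(F)F)cc(C(F)(F)F)c4)c3)cc2-c2ccncc2)c1` has not yet been measured. It differs from compound 2 by a single change: methyl in place of hydrogen on an oxygen on an aromatic ring. Within the data shown here, compound 1 also carries a methoxy group, and compound 1 gives the weaker number of the two, 43.7%, but it differs in its trifluoromethyl count as well, so no step for this change alone is known. A modest step towards a higher number, perhaps within the scatter, is expected: a number 8.8 percentage points higher from compound 2 to compound 3 (within the scatter). Compound 3 is expected to give about 30%, within a range from 12% to 50%.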

Compound 3, a percentage reported as activity, at one concentration (the size of the read-out at that concentration, not a potency): 55.5%
Compound 3: middle estimate off by 25.5 percentage points, on the low side; measured number outside the range, above it.
By their numbers in this assay, from the lowest: compound 2; then compound 1; then compound 3.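

In this assay, the change from 3-chloro-5-hydroxyphenyl to 3-chloro-5-methoxyphenyl can now be read on its own, with both trifluoromethyl groups kept, and it gives a number 34.3 percentage points higher from compound 2 to compound 3 (beyond the scatter), so in this pair the lower number goes with the free hydroxy. The second trifluoromethyl can also now be read on its own, with the methoxy kept: trifluoromethyl in place of hydrogen on an aromatic carbon gives a number 11.8 percentage points higher from compound 1 to compound 3 (beyond the scatter), so in this pair the added group goes with a higher number, not a lower one. These two steps describe what changes but not why, and nothing measured here bears on the cause.

From the compounds shown here alone, how the hydroxy group behaves alongside a single trifluoromethyl stays open, so these compounds cannot show whether the two steps simply add up or depend on each other. Going by these compounds, it is also open how the read-out would respond at this place to an ethoxy group, with a longer chain on the oxygen, or to an amine in place of the hydroxy.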